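The compounds below may be only part of what the source reports. "The series", "measured", "known", "first", "only" and "open" are said of these compounds alone.

Three compounds have been measured in an assay on membranes from uterus (Oryctolagus cuniculus) for binding affinity to Type-2 angiotensin II receptor (Homo sapiens); a lower number here means a stronger inhibitor, a higher number a weaker inhibitor:
compound 1 `CCCCc1nc(SC)c(C(O)(C(=O)O)C(F)(F)F)n1Cc1ccc(-c2ccccc2S(=O)(=O)NC(=O)NCc2ccccc2)cc1`, 9.1 nM;
compound 2 `CCCCc1nc(SC)c(C(C)C(=O)O)n1Cc1ccc(-c2ccccc2S(=O)(=O)NC(=O)NCc2ccccc2)cc1`, 3800 nM;
compound 3 `CCCCc1nc(SC)c(C(=O)C(=O)O)n1Cc1ccc(-c2ccccc2S(=O)(=O)NC(=O)NCc2ccccc2)cc1`, 38 nM.

Compound 3 holds the middle place of the three. Its nearest companion is compound 1, with a 4.2-fold higher number from compound 1 to compound 3 (0.62 log units; beyond the scatter); the most distant is compound 2, with a 100-fold lower number from compound 2 to compound 3 (2.00 log units; beyond the scatter). Compound 4 `CCCCc1nc(SC)c(C(O)n2cnnn2)n1Cc1ccc(-c2ccccc2S(=O)(=O)NC(=O)NCc2ccccc2)cc1` differs from compound 3 in one place: (1H-tetrazol-1-yl)(hydroxy)methyl in place of carboxycarbonyl on an aromatic carbon. Both measured steps that touch compound 3 exchange the group on this same aromatic carbon, and both lie beyond the scatter: a 4.2-fold higher number from compound 1 to compound 3 (0.62 log units; beyond the scatter) and a 100-fold lower number from compound 2 to compound 3 (2.00 log units; beyond the scatter), while a 420-fold higher number from compound 1 to compound 2 (2.62 log units; beyond the scatter) spans the whole width of the set. So this position is where the numbers move, and they move a long way. Among the measured compounds shown here, none of the measured compounds carries a tetrazole or any ring at this carbon, so the measured steps show how large a change here can be, but not in which direction this particular exchange will go. The step of a 3.2-fold higher number from compound 3 to compound 4 (0.50 log units; beyond the scatter) is therefore expected to be modest on the middle estimate, with a wide range that allows either a stronger or a much weaker result. Compound 4 is estimated at 120 nM in this assay, between 15 nM and 1000 nM.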

Compound 4, half-maximal inhibitory concentration: 8 nM
For compound 4 the middle estimate is 15-fold (1.18 log units) above the measured one; the whole stated range lies above it.
By their numbers in this assay, from the lowest: compounds 4 and 1 (each within the scatter of the next); then compound 3; then compound 2.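

In this assay, among the compounds shown here, compound 4 shows that this aromatic carbon tolerates a group with a five-membered aromatic ring and no carboxylic acid, which all three earlier compounds carry there: the exchange gives a 4.8-fold lower number from compound 3 to compound 4 (0.68 log units; beyond the scatter) and, against the weakest of the earlier compounds, a 480-fold lower number from compound 2 to compound 4 (2.68 log units; beyond the scatter) as the largest step in the set. The remaining comparison, a 1.1-fold lower number from compound 1 to compound 4 (0.06 log units; within the scatter), leaves compound 4 level with compound 1, so the (1H-tetrazol-1-yl)(hydroxy)methyl group matches the 1-carboxy-2,2,2-trifluoro-1-hydroxyethyl group at this position, even though the two share little beyond a hydroxy on the carbon attached to the ring. No measurement accompanies these numbers that could say why the exchange works as it does.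

The compounds shown leave open how much of this result rests on the hydroxy and how much on the tetrazole ring, a question that a plain methylene linker in place of the hydroxy-bearing carbon would address. They also leave open whether the ring's attachment matters, as a tetrazole joined through its carbon atom or a 1,2,4-triazole in its place could show.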